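The compounds below may be only part of what the source reports. "The series", "measured", "known", "first", "only" and "open" are said of these compounds alone.

In an ADME assay on the whole organism for inhibition, with Triticum aestivum as the target, with a stated time of 5 days (a lower number here means a stronger inhibitor, a higher number a weaker inhibitor), compound 1 `CCCCC(=O)ON1C(=O)COc2ccc(Cl)cc21` gives 26600 nM. Compound 2 `O=C1C(c2ccccc2)Oc2ccc(F)cc2N1O` gives 641000 nM in this assay, and compound 3 `O=C1C(c2ccccc2)Oc2ccc(Cl)cc2N1O` gives 690000 nM. Compound 1 thus stands lowest of the three measured numbers, with compound 2 nearest and compound 3 furthest, and both gaps lie beyond the usual scatter. How the core of compound 1 differs from the core of compound 3 is not broken down here.

Compounds 3 and 2 differ in one place: fluoro in place of chloro on an aromatic carbon This change made a 1.1-fold lower number from compound 3 to compound 2 (0.03 log units; within the scatter).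

Compound 4 `CCCCC(=O)ON1C(=O)COc2ccc(F)cc21` has not yet been measured in this assay. It differs from compound 1 by the same change, at the same place: fluoro in place of chloro on an aromatic carbon Among the compounds shown this change occurs twice in all, once measured and once not. Because the measured instance gave a 1.1-fold lower number from compound 3 to compound 2 (0.03 log units; within the scatter), the expected step is a 1.1-fold lower number from compound 1 to compound 4 (0.03 log units; within the scatter), which is to say essentially no change. That expectation rests on a single measured pair, compounds 3 and 2, whose shared core differs from the core of compound 1 in a way that is not broken down here, so the range around the estimate is kept wide. Compound 4 is therefore estimated to give 25000 nM in this assay, with the likely range running from 10000 nM to 65000 nM.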

Compound 4, half-maximal inhibitory concentration: 58200 nM
Compound 4: middle estimate off by 2.3-fold (0.37 log units), on the low side, and the stated range covers the measured number.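

On the core of compound 1, fluoro in place of chloro on an aromatic carbon gave a 2.2-fold higher number from compound 1 to compound 4 (0.34 log units; beyond the scatter) in this assay, a modest step that lies beyond the usual scatter, unlike the earlier step on the other core. Even so, the two steps cannot be told apart, as the gap between them lies within the scatter expected of two such steps: the same change on two cores in this assay, a 1.1-fold lower number (0.03 log units; within the scatter) from compound 3 to compound 2 and a 2.2-fold higher number (0.34 log units; beyond the scatter) from compound 1 to compound 4, 2.4-fold (0.37 log units) apart, within the scatter of two such steps. Among these compounds, this fits the change carrying from one core to the other, but it rests on only two matched pairs, so it does not establish that the step is the same on both cores, nor does it show what size or direction the step would take on any further core.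

The compounds shown leave open how other groups on the same aromatic carbon, such as bromo, methyl or methoxy, would compare with fluoro and chloro on either core. They also leave open whether the step from chloro to fluoro would hold if the ester chain of compound 1 and compound 4 were replaced by a shorter chain, a longer chain or an amide.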